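The source may hold more compounds than are shown below. What is called first, only, known or untested is meant among the compounds shown, and "the series" means these compounds.

Measured so far in a functional assay on the whole organism (stomach) with Rattus norvegicus as the target; on this read-out higher numbers stand for an effect only at larger amounts of compound and lower numbers for an effect already at smaller amounts:
- compound 1 `CCCC[C@@](C)(OC)[C@@H](O)/C=C/C1[C@H](O)CC(=O)[C@@H]1CCCCCCC(=O)OC`: > 1 mg/kg (a limit of the assay, not a number)
- compound 2 `CCCC[C@](C)(OC)[C@H](O)/C=C/C1[C@H](O)CC(=O)[C@@H]1C/C=C\CCCC(=O)OC`: 0.5 mg/kg
- compound 3 `CCCC[C@@](C)(OC)[C@H](O)/C=C/C1[C@H](O)CC(=O)[C@@H]1C/C=C\CCCC(=O)OC`: 0.0072 mg/kg

Compound 3 gives the lowest of the two numbers obtained in this assay. Among the compounds with values here, the only step measured in one place is a 69-fold lower number from compound 2 to compound 3 (1.84 log units; beyond the scatter); the two compounds differ at a stereocentre at a saturated chain carbon, and the fact that one of compounds 2 and 3 is drawn with a defined configuration and the other without, at the place where they differ is the sole feature that separates them. Within the data shown here, for compound 1 this assay reports only a limit, (the limit of > 1 mg/kg in this assay, at which 1 of the 3 values shown sits); compound 1 differs from compound 3 both in the saturated chain and at a further stereocentre, so no single-place step leads from it to compound 4.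

The unmeasured compound 4 `CCCC[C@@](C)(OC)[C@H](O)/C=C/C1[C@H](O)CC(=O)[C@@H]1CCCCCCC(=O)OC` is reached from compound 3 by 5-(methoxycarbonyl)pentyl in place of 5-(methoxycarbonyl)pent-1-en-1-yl on a saturated chain carbon bound to a saturated ring carbon. Among the measured compounds shown here, no measured step addresses this change alone. The stereo step from compound 2 to compound 3 does not bear on a change in chain saturation. The limit of compound 1 shows that a saturated-chain member of this series can fall outside the measured window, but its second difference leaves that unresolved. A moderate loss is therefore expected, a 4.2-fold higher number from compound 3 to compound 4 (0.62 log units; beyond the scatter), with wide uncertainty. For compound 4 the estimate in this assay is 0.03 mg/kg, within 0.005 mg/kg to 0.3 mg/kg.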

Compound 4, dose for 50% inhibition: 0.0045 mg/kg
Compound 4: the middle estimate sits 6.7-fold (0.82 log units) above what was measured; measured number below the stated range.
By their numbers in this assay, from the lowest: compounds 4 and 3 (each within the scatter of the next); then compound 2. At a limit, above all of these: compound 1.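

In this assay, 5-(methoxycarbonyl)pentyl in place of 5-(methoxycarbonyl)pent-1-en-1-yl on a saturated chain carbon bound to a saturated ring carbon gives a 1.6-fold lower number from compound 3 to compound 4 (0.20 log units; within the scatter), so with this configuration the double bond in this chain makes no difference that the assay can resolve. For compound 1, the value > 1 mg/kg is a limit of the assay, not a number. With the saturated chain common to both compounds, the gap to the earlier limit now reads as an at least 220-fold lower number from compound 1 to compound 4 (2.34 log units; beyond the scatter), which involves a second stereocentre at a saturated chain carbon, not the one that separates compound 2 and compound 3, and the sole feature separating this pair is: the fact that one of compounds 1 and 4 is drawn with a defined configuration and the other without, at the place where they differ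

From the compounds shown here alone, how a carboxylic acid in place of the methoxycarbonyl end of the chain, or a longer chain, would read in this assay remains open. Also open, going by these compounds, is whether the chain double bond is equally dispensable with other configurations at these two stereocentres, since the step from compound 3 to compound 4 covers only one combination.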